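The source may hold more compounds than are shown below. What is called first, only, known or untested is meant among the compounds shown, and "the series" means these compounds.

Compound 1 `COc1ccc(/C=N/NC(=O)Nc2ccc(Oc3ccnc(-c4nncn4CCN(C)C)c3)c(F)c2)c(OC)c1OC` gives 6680 nM in a functional assay on A549 cells (Homo sapiens) for cytotoxicity, read by MTT assay, with a stated time of 72 h; a lower number here means a stronger inhibitor, a higher number a weaker inhibitor. Compound 2 `COc1cc(/C=N/NC(=O)Nc2ccc(Oc3ccnc(-c4nncn4CCN(C)C)c3)c(F)c2)cc(OC)c1OC` reports only > 100000 nM in this assay, a limit rather than a number. Compound 2 therefore stands at the weak end of the pair, at the limit of > 100000 nM in this assay, at which 1 of the 2 values shown sits. The step of an at least 14-fold higher number from compound 1 to compound 2 (1.17 log units; beyond the scatter) shows that the aryl group on the carbon with a double bond to nitrogen moves the number strongly. Compound 3 `CN(C)CCn1cnnc1-c1cc(Oc2ccc(NC(=O)N/N=C/c3cccc(Br)c3)cc2F)ccn1` carries 3-bromophenyl in place of 3,4,5-trimethoxyphenyl on a carbon with a double bond to nitrogen. Within the data shown here, only that one step bears on this change, and neither measured aryl matches 3-bromophenyl, so the expected direction is uncertain; a step of an at least 4.0-fold lower number from compound 2 to compound 3 (0.60 log units; beyond the scatter) is expected. Compound 3 is estimated at 25000 nM, within 4000 nM to 100000 nM.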

Compound 3, half-maximal inhibitory concentration: 970 nM
Compound 3: middle estimate off by 26-fold (1.41 log units), on the high side, and the stated range ends above it.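

Compound 3 shows that a trimethoxyphenyl group is not needed on this carbon with a double bond to nitrogen for activity in this assay: 3-bromophenyl gives a 6.9-fold lower number from compound 1 to compound 3 (0.84 log units; beyond the scatter), and also an at least 100-fold lower number from compound 2 to compound 3 (2.01 log units; beyond the scatter). The second step has no exact size, as compound 2 remains a limit: the limit of > 100000 nM in this assay, at which 1 of the 3 values shown sits.

Among these compounds, whether the bromine itself drives this gain remains open, since 3-bromophenyl is the only halogenated aryl group here. Plain phenyl, 3-chlorophenyl or 3-aminophenyl would separate the bromine from the loss of the methoxy groups.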